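Swapping a Sulfonamide for a Urea on the Ring Nitrogen

This account rests on a few compounds, and the source may have more. Where it says the series, first, only, none or still open, it means among the compounds named here.

Compound 1 `O=C(C1CCCO1)N1CCc2nc(C#Cc3ccccc3)sc2C1`: in an assay on HEK293 cells for negative allosteric modulation of metabotropic glutamate receptor 5 (Homo sapiens), read by FLIPR, with a stated time of 1 h (on this read-out lower numbers stand for stronger inhibition and higher numbers for weaker inhibition), compound 1 shows only the limit > 10000 nM, not a number.
Compound 2 `O=S(=O)(C1CC1)N1CCc2nc(C#Cc3ccccc3)sc2C1`: in this assay compound 2 gives 34 nM.

Compound 2 holds the only number shown; compound 1 sits at the assay limit (the limit of > 10000 nM in this assay, at which 1 of the 2 values shown sits). Among the compounds with values here, the one measured step, an at least 290-fold lower number from compound 1 to compound 2 (2.46 log units; beyond the scatter), runs from a carbonyl-linked group to the sulfonyl. Compound 3 `O=C(N1CCCC1)N1CCc2nc(C#Cc3ccccc3)sc2C1` differs from compound 2 by (pyrrolidin-1-yl)carbonyl in place of cyclopropylsulfonyl on an amine nitrogen in a ring, returning to a carbonyl-linked group. Because the step of an at least 290-fold lower number from compound 1 to compound 2 (2.46 log units; beyond the scatter) was large in favour of the sulfonyl, compound 3 is expected to lose a large part of it, a 59-fold higher number from compound 2 to compound 3 (1.77 log units; beyond the scatter). Compound 3 is therefore estimated at 2000 nM, within 200 nM to 10000 nM.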

Compound 3, half-maximal inhibitory concentration: > 10000 nM
Compound 3: only a limit was reported; the forecaster's own chance of this, stated with the estimate: 35%; middle value at least 5.0-fold (0.69 log units) from the limit.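

In this assay, (pyrrolidin-1-yl)carbonyl in place of cyclopropylsulfonyl on the amine nitrogen in a ring gives an at least 290-fold higher number from compound 2 to compound 3 (2.46 log units; beyond the scatter), so a second carbonyl-linked group, now with a nitrogen on the carbonyl carbon, also loses the activity of compound 2. Compound 3 gives only a limit, > 10000 nM, and the step between compound 1 and compound 3 cannot be read. Both carbonyl-linked compounds end at the same limit: the limit of > 10000 nM in this assay, at which 2 of the 3 values shown sit.

As far as these compounds go, whether a methyl or a phenyl on the sulfonyl would keep the activity of compound 2 stays open. From the compounds shown here alone, how far compound 1 and compound 3 differ from each other also stays open.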